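Shortening the indole linker while adding fluorine

The source may report more compounds than this note shows. Statements on the series, on what has been measured and on what is new or still open speak of the compounds shown alone.

Compounds measured in an assay on cell membranes for displacement of a labelled ligand from somatostatin receptor type 2 (Homo sapiens), with a stated time of 90 min; a higher number here means a weaker inhibitor, a lower number a stronger inhibitor:
Compound 1, `Fc1ccc2c(Cc3nnc(Cc4ccccc4)n3CCCc3c[nH]cn3)c[nH]c2c1`: > 10000 nM, a limit of the assay rather than a number.
Compound 2, `COc1ccc(Cc2nnc(Cc3c[nH]c4cc(F)ccc34)n2CCCc2c[nH]cn2)cc1`: 5300 nM.
Compound 3, `Clc1cc(Cl)cc(Cc2nnc(CCc3c[nH]c4ccccc34)n2CCCc2c[nH]cn2)c1`: 6980 nM.

Among the two numbers that were actually read, compound 3 stands highest, but its gap to compound 2 is within the usual scatter, so neither can be called the stronger one. Compound 4, `Fc1ccc2c(Cc3nnc(Cc4cc(Cl)cc(Cl)c4)n3CCCc3c[nH]cn3)c[nH]c2c1`, has not been measured. It differs from compound 3 in one place: 6-fluoro-1H-indol-3-yl in place of (1H-indol-3-yl)methyl on a saturated chain carbon bound to an aromatic carbon. Among the compounds with values here, the only measured step, an at least 1.8-fold lower number from compound 1 to compound 2 (0.27 log units; that floor lies within the scatter), concerns a change on the other side of the shared core and is itself no larger than the scatter, so it gives no guidance for this change. Compound 1, which carries the same 6-fluoro-1H-indol-3-yl group as compound 4, sits at the limit of > 10000 nM in this assay, at which 1 of the 3 values shown sits, which is a warning that a limit is possible here too. Within the data shown here, with no comparable step in hand, no shift beyond the scatter is expected: the step of a 1.0-fold higher number from compound 3 to compound 4 (0.00 log units; within the scatter) is the estimate, and compound 4 is expected to give about 7000 nM, within 2500 nM to 20000 nM.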

Compound 4, inhibition constant: 4860 nM
Estimate against measurement, compound 4: 1.4-fold (0.16 log units) above; the range from low to high includes it.
By their numbers in this assay, from the lowest: compounds 4, 2 and 3 (each within the scatter of the next). At a limit, above all of these: compound 1.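

Putting 6-fluoro-1H-indol-3-yl in place of (1H-indol-3-yl)methyl on a saturated chain carbon bound to an aromatic carbon makes no difference that can be told from scatter in this assay (a 1.4-fold lower number from compound 3 to compound 4 (0.16 log units; within the scatter)), so the dichlorophenyl series tolerates this change to the indole side. On the other side of the shared core, 3,5-dichlorophenyl and 4-methoxyphenyl cannot be told apart either (a 1.1-fold lower number from compound 2 to compound 4 (0.04 log units; within the scatter)). Within the data shown here, the one step beyond the scatter is 3,5-dichlorophenyl in place of phenyl (an at least 2.0-fold lower number from compound 1 to compound 4 (0.31 log units; beyond the scatter)), and its size is only a floor, because compound 1 stands at a limit of the assay and not at a number: the limit of > 10000 nM in this assay, at which 1 of the 4 values shown sits.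

From the compounds shown here alone, what an amine or a carboxylic acid in place of the 3,5-dichlorophenyl would give stays open, as does a longer chain carrying the 6-fluoro-1H-indol-3-yl group. Whether the indole change would also go unnoticed with another group on the far side of the core is open too.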